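The source may report more compounds than this note shows. Statements on the series, on what has been measured and on what is new or still open speak of the compounds shown alone.

In a functional assay on CCRF-CEM cells (Homo sapiens) for antiproliferative activity, read by trypan blue exclusion, with a stated time of 72 h (on this read-out lower numbers stand for stronger inhibition and higher numbers for weaker inhibition), compound 1 `Cc1c(NC(=O)C(C)Br)cccc1C(=O)NC(N)=O` gives 480 nM and compound 2 `Cc1ccc(C(=O)NC(N)=O)cc1NC(=O)C(C)Br` gives 3360 nM. Compound 3 `Cc1ccc(NC(=O)C(C)Br)cc1C(=O)NC(N)=O` reaches a limit of the assay rather than a number, > 20000 nM. Compound 2 therefore has the higher of the two actual numbers, and its gap to compound 1 lies beyond the usual scatter of repeated measurements. Compound 4 `CC(Br)C(=O)Nc1cc(C(=O)NC(N)=O)ccc1Cl` differs from compound 2 in one place: chloro in place of methyl on an aromatic carbon. For the measured compounds named here, this is chloro in place of methyl on an aromatic carbon, and no measured pair shows this swap. Starting from compound 2 at 3360 nM, no step beyond the scatter is expected in this assay, in either direction. The estimated change is small, a 1.3-fold lower number from compound 2 to compound 4 (0.13 log units; within the scatter). Compound 4 is expected at 2500 nM, with an estimated range of 800 nM to 9000 nM.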

Compound 4, half-maximal inhibitory concentration: 9800 nM
Compound 4: middle estimate off by 3.9-fold (0.59 log units), on the low side; the whole stated range lies below it.
By their numbers in this assay, from the lowest: compound 1; then compound 2; then compound 4. At a limit, above all of these: compound 3.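

In this assay, chloro in place of methyl gives a 2.9-fold higher number from compound 2 to compound 4 (0.46 log units; beyond the scatter), a modest weakening, although each group is a single heavy atom without hydrogen-bond donors or acceptors. This place, ortho to a ((1-bromoethyl)carbonyl)amino group and para to a carbamoylcarbamoyl group, therefore responds even to a one-atom swap. The result for compound 3 is a limit rather than a number, and compound 4 does not reach it: the limit of > 20000 nM in this assay, at which 1 of the 4 values shown sits.

On these data alone, whether an amine, a methoxy group or a longer chain here would give a lower or higher number remains open.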